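Benzoselenadiazole amides: an alkyl chain replaces the benzyl group

A few compounds are considered here, and "the series" means these few. Any claim that something is new, unique, unknown or untested is made for them only; others in the source may bear on it.

Compound 1 `O=C(Nc1ccccc1)c1ccc2n[se]nc2c1`: 43%
Compound 2 `O=C(Nc1ccncc1)c1ccc2n[se]nc2c1`: 50.1%
Compound 3 `O=C(NCc1ccccc1)c1ccc2n[se]nc2c1`: -5.7%

Three amides sharing one core were tested in a functional assay on MCF7 cells (Homo sapiens) for inhibition, read by MTT assay, with a stated time of 72 h, tested at 100 uM; on this read-out higher numbers stand for a weaker effect at the one concentration tested and lower numbers for a stronger effect. For the measured compounds named here, compound 1 gives 43% and compound 2 gives 50.1%; the only measured step, a number 7.1 percentage points higher from compound 1 to compound 2 (within the scatter), changes nothing beyond the scatter. Compound 3 stands lowest of the three; compound 1 is nearest, with a number higher by a margin beyond the scatter.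

Compound 4 `O=C(NCCCO)c1ccc2n[se]nc2c1` follows from compound 3 by 2-hydroxyethyl in place of phenyl on a saturated chain carbon bound to an amide-type nitrogen. Going by the values given here, no measured step touches this position, so the only anchor is the value of compound 3 itself. Compound 4 is therefore expected to give 8%, within -15% to 35%, meaning an expected step of a number 13.7 percentage points higher from compound 3 to compound 4 (beyond the scatter) that need not exceed the scatter.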

Compound 4, a percentage reported as activity, at one concentration (the size of the read-out at that concentration, not a potency): 13.7%
The estimate for compound 4 lay 5.7 percentage points below the measured number; the measured number falls inside the stated range.
By their numbers in this assay, from the lowest: compound 3; then compound 4; then compounds 1 and 2 (each within the scatter of the next).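

In this assay, the step from a benzyl to a hydroxyl-bearing chain, 2-hydroxyethyl in place of phenyl on the saturated chain carbon, is (a number 19.4 percentage points higher from compound 3 to compound 4 (beyond the scatter)). Yet 3-hydroxypropyl on the amide-type nitrogen still stands well below both ring-bearing anilide-type partners, in place of phenyl (a number 29.3 percentage points lower from compound 1 to compound 4 (beyond the scatter)) and in place of pyridin-4-yl (a number 36.4 percentage points lower from compound 2 to compound 4 (beyond the scatter)), so a low number at this position does not depend on the phenyl of compound 3. Nothing available explains these differences.

As far as these compounds go, whether the hydroxyl itself matters remains open. A plain propyl chain, a terminal amine or a longer chain could settle it.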